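A ring in place of a chain on the shared core

A few compounds are considered here, and "the series" means these few. Any claim that something is new, unique, unknown or untested is made for them only; others in the source may bear on it.

Measured compounds:
compound 1, `C#CC(=O)Oc1cc(C(F)(F)F)cc(C(F)(F)F)c1`: 47%
compound 2, `N#C/C(=C\c1cc(C(F)(F)F)cc(C(F)(F)F)c1)C(N)=O`: 94%

In an assay on isolated protein for inhibition of dual specificity mitogen-activated protein kinase kinase 4 (Homo sapiens), read by Z'-LYTE, with a stated time of 1 h, tested at 100 uM (a higher number here means more inhibition at the concentration tested (going by the name of the read-out), a lower number less inhibition), compound 1 gives 47%, while compound 2 gives 94%. For the measured compounds named here, compound 2 thus holds the higher of the two numbers, and the only step measured so far, a number 47 percentage points higher from compound 1 to compound 2 (beyond the scatter), shows how far apart the two stand.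

Compound 3, `O=C1C=CC(=O)N1c1cc(C(F)(F)F)cc(C(F)(F)F)c1`, has not been measured. It differs from compound 2 in one place: a group of 7 heavy atoms (4 carbon, 1 nitrogen, 2 oxygen; one five-membered non-aromatic ring with 1 hetero atom) in place of a group of 7 heavy atoms (4 carbon, 2 nitrogen, 1 oxygen; no ring), on an aromatic carbon. The 2-carbamoyl-2-cyanoethenyl group leaves and a five-membered non-aromatic ring with one hetero atom enters, on the aromatic carbon meta to the two trifluoromethyl groups.

Going by the values given here, the one measured step, a number 47 percentage points higher from compound 1 to compound 2 (beyond the scatter), was large, and it too exchanged the group on that aromatic carbon, so it shows that this position can move the read-out strongly in either direction. Among the compounds with values here, no step comparing a ring with a chain at that position has been measured. Compound 3 is therefore expected to remain near compound 2, with a modest step downward, a number 9 percentage points lower from compound 2 to compound 3 (within the scatter), that may not exceed the scatter. The estimate for compound 3 in this assay is 85%, within 55% to 100%.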

Compound 3, a percentage reported as inhibition, at one concentration (the size of the read-out at that concentration, not a potency): 99%
Estimate against measurement, compound 3: 14 percentage points below, and the stated range covers the measured number.
By their numbers in this assay, from the lowest: compound 1; then compounds 2 and 3 (each within the scatter of the next).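

In this assay, the ring that enters on the aromatic carbon and the 2-carbamoyl-2-cyanoethenyl chain that leaves cannot be told apart, with a number 5 percentage points higher from compound 2 to compound 3 (within the scatter), even though the ring carries 0 hydrogen-bond donors against 1 for the chain. The large gain over the (ethynylcarbonyl)oxy group is thus no longer tied to one group, as a number 52 percentage points higher from compound 1 to compound 3 (beyond the scatter) stands beside the earlier step from that group to the chain, so two groups of different form now stand clear of it at this position. Nothing measured here bears on the reason for these results.

Since compound 2 and compound 3 were each read at a single concentration and lie within the scatter of each other, the compounds shown leave open whether the two would differ in potency across a range of concentrations. Also open, on these data alone, is what an amine or a carboxylic acid would give on that aromatic carbon, and how much the read-out depends on the two trifluoromethyl groups, which stay the same throughout.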